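From 4-ethylphenyl to furan-2-yl on the shared core

The compounds below may be only part of what the source reports. "The series", "measured", "known", "first", "only" and "open" are said of these compounds alone.

- compound 1 `COC1=C(C)C(=O)/C(=C(O)/C=C/c2ccc(OC)cc2)C(=O)C1(C)C` gives 5.6 ug/mL
- compound 2 `COC1=C(C)C(=O)/C(=C(O)/C=C/c2cccc(OC)c2)C(=O)C1(C)C` gives 2.9 ug/mL
- compound 3 `CCc1ccc(/C=C/C(O)=C2/C(=O)C(C)=C(OC)C(C)(C)C2=O)cc1` gives 10.5 ug/mL

In a functional assay on HCT-8 cells (Homo sapiens) for cytotoxicity (on this read-out higher numbers stand for an effect only at larger amounts of compound and lower numbers for an effect already at smaller amounts), compound 3 (10.5 ug/mL) stands at the upper end of the numbers shown. It is separated from the others by a 1.9-fold higher number from compound 1 to compound 3 (0.27 log units; within the scatter) and by a 3.6-fold higher number from compound 2 to compound 3 (0.56 log units; beyond the scatter) so only the second of these gaps is a real one.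

The next compound is compound 4 `COC1=C(C)C(=O)/C(=C(O)/C=C/c2ccco2)C(=O)C1(C)C` and its change is furan-2-yl in place of 4-ethylphenyl on a double-bonded chain carbon bound to a double-bonded chain carbon in which furan-2-yl takes the place of 4-ethylphenyl on a double-bonded chain carbon bound to a double-bonded chain carbon. All three measured steps act at this same place. Besides the two above, there is a 1.9-fold lower number from compound 1 to compound 2 (0.29 log units; within the scatter) and so the largest step seen at this place is still modest. Within the data shown here, none of the measured compounds carries furan-2-yl, which leaves the size of this particular swap open. The three values give only a narrow span to reason from, and compound 3 sits at its upper end, so a move towards lower numbers is the likelier direction. The expected step is a 1.9-fold lower number from compound 3 to compound 4 (0.28 log units; within the scatter) and no larger move is anticipated. Compound 4 is estimated at 5.5 ug/mL within an expected range of 2.2 ug/mL to 13 ug/mL on this read-out.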

Compound 4, concentration for half-maximal effect: 17.5 ug/mL
Beside the measured number, compound 4's estimate is 3.2-fold (0.50 log units) below it, outside the stated range (above it).
By their numbers in this assay, from the lowest: compounds 2, 1, 3 and 4 (each within the scatter of the next, the first and the last beyond it).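

In this assay, among these compounds, furan-2-yl is the first five-membered aromatic ring with a hetero atom at this place, and replacing 4-ethylphenyl with it gives a 1.7-fold higher number from compound 3 to compound 4 (0.22 log units; within the scatter), so a ring of 5 heavy atoms in place of one with 8 leaves no readable difference from that group. Set against the two methoxyphenyl groups, the same ring does open real gaps, with a 3.1-fold higher number from compound 1 to compound 4 (0.49 log units; beyond the scatter) and a 6.0-fold higher number from compound 2 to compound 4 (0.78 log units; beyond the scatter), the latter being the largest step printed so far on this double-bonded chain carbon, though still a modest one. The two methoxyphenyl compounds thus both stand apart from the furan-2-yl compound, but compound 3 blurs any clean split by ring type, since it lies within the scatter of both compound 1 and compound 4 and beyond it only from compound 2.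

No measurement here offers an explanation for these gaps. Because furan-2-yl changes ring size and brings in a ring oxygen at once, the compounds shown cannot separate the two, and they leave open where an unsubstituted phenyl, a thiophen-2-yl or a 4-aminophenyl would fall.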